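A Hydroxy Group on Two Cores Against Breast Cancer Cells

This account rests on a few compounds, and the source may have more. Where it says the series, first, only, none or still open, it means among the compounds named here.

Compound 1 `Cn1c(/C=C/C(=O)c2ccccc2)cc(Br)c1Br` and compound 2 `Cn1c(/C=C/C(=O)c2cccc(O)c2)cc(Br)c1Br` share one core, while compound 3 `Cn1c(-c2cc(-c3ccccc3)no2)cc(Br)c1Br` and compound 4 `Cn1c(-c2cc(-c3ccccc3O)no2)cc(Br)c1Br` share another; the difference between the two cores is not broken down here. In a functional assay on MCF7 cells (Homo sapiens) for cytotoxicity, read by MTT assay, with stated times of 6 h and 48 h (a higher number here means a weaker inhibitor, a lower number a stronger inhibitor), compound 1 gives 35400 nM. Compound 2 gives 12800 nM in this assay. The change between these two, (hydroxy in place of hydrogen on an aromatic carbon), produced a 2.8-fold lower number from compound 1 to compound 2 (0.44 log units; beyond the scatter). For compound 3 this assay returns only a limit, >= 100000 nM, one of the values sitting at the limit of >= 100000 nM in this assay, at which 1 of the 3 values shown sits. Compound 4 carries the same kind of change, (hydroxy in place of hydrogen on an aromatic carbon), yet its place is not identical: in compound 4 the hydroxy stands ortho to a large group, in compound 2 meta to a large group, so the two changes are alike in kind but not the same. Because compound 3 is known only as a limit, the expectation for compound 4 rests mainly on a 2.8-fold lower number from compound 1 to compound 2 (0.44 log units; beyond the scatter), carried over to the other core. The expected step is an at least 1.2-fold lower number from compound 3 to compound 4 (0.09 log units; that floor lies within the scatter). Compound 4 is estimated at 80000 nM, between 30000 nM and 200000 nM, with a fair chance that the assay again reports only a limit.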

Compound 4, half-maximal inhibitory concentration: >= 100000 nM
Compound 4: only a limit was reported; the forecaster's own chance of this, stated with the estimate: 55%; at least 1.2-fold (0.09 log units) between middle value and limit.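

In this assay, compound 3 and compound 4 are both known only as limits, so no step between them can be read: the limit of >= 100000 nM in this assay, at which 2 of the 4 values shown sit.

The compounds shown leave open whether hydroxy in place of hydrogen changes the number at all on the core of compound 3, as it did from compound 1 to compound 2 on the other core.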